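This account rests on a few compounds, and the source may have more. Where it says the series, first, only, none or still open, it means among the compounds named here.

The study sets three measured compounds against one still untested in an assay for inhibition of Fatty-acid amide hydrolase 1 (Rattus norvegicus); a higher number here means a weaker inhibitor, a lower number a stronger inhibitor. Compound 1 `NC(=O)c1cnc(C(=O)CCc2ccc(Oc3ccccc3)cc2)o1` gives 6.6 nM in this assay. Compound 2 `COC(=O)c1ccc(-c2cnc(C(=O)CCc3ccc(-c4ccccc4)cc3)o2)nc1` gives 2.2 nM. Compound 3 `O=C(O)c1cc(-c2cnc(C(=O)CCc3ccc(-c4ccccc4)cc3)o2)ccn1` gives 50 nM, the highest of the three numbers; its gap to compound 1 and its larger gap to compound 2 both lie beyond the scatter. Within the data shown here, the only single-place step recorded is a 23-fold higher number from compound 2 to compound 3 (1.36 log units; beyond the scatter). That step replaces a whole 5-(methoxycarbonyl)pyridin-2-yl with 2-carboxypyridin-4-yl, so it bundles the loss of the methoxycarbonyl with a change in the ring itself, and it bears on the present question only in part.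

Compound 4 `COC(=O)c1cc(-c2cnc(C(=O)CCc3ccc(-c4ccccc4)cc3)o2)ccn1` differs from compound 3 by methyl in place of hydrogen on an oxygen next to a carbonyl group, which reads 2-carboxypyridin-4-yl to 2-(methoxycarbonyl)pyridin-4-yl. The change restores the methoxycarbonyl seen in compound 2 while leaving the ring as it stands in compound 3. Among the measured compounds shown here, with the mixed step as the only guide, one expects a move toward lower numbers, beyond the scatter but smaller than that mixed step, since part of that step need not come from the methoxycarbonyl. The estimate therefore means a 5.6-fold lower number from compound 3 to compound 4 (0.74 log units; beyond the scatter). Compound 4 is expected to give 9 nM, with a range from 2.5 nM to 30 nM.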

Compound 4, inhibition constant: 1.5 nM
The estimate for compound 4 lay 6.0-fold (0.78 log units) above the measured number; measured number outside the range, below it.
By their numbers in this assay, from the lowest: compounds 4 and 2 (each within the scatter of the next); then compound 1; then compound 3.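

In this assay, methyl in place of hydrogen on an oxygen next to a carbonyl group gives a 33-fold lower number from compound 3 to compound 4 (1.52 log units; beyond the scatter), so the carboxy to methoxycarbonyl change alone carries a large step on the 2-carboxypyridin-4-yl group, which the earlier mixed step could not show. The matching comparison of the two methoxycarbonyl compounds is a 1.5-fold lower number from compound 2 to compound 4 (0.17 log units; within the scatter), so 2-(methoxycarbonyl)pyridin-4-yl in place of 5-(methoxycarbonyl)pyridin-2-yl on an aromatic carbon leaves the number within the scatter. Read together, these two steps tie the earlier 23-fold higher number from compound 2 to compound 3 (1.36 log units; beyond the scatter) in these compounds to the presence of the carboxy group, with no change beyond the scatter left for the move between the two methoxycarbonyl-bearing groups.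

Nothing available here explains the gap between the carboxy and methoxycarbonyl compounds. The compounds shown leave open whether an ethoxycarbonyl or a hydroxymethyl group at this place would read like the methoxycarbonyl of compound 4 or like the carboxylic acid of compound 3.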